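A few compounds are considered here, and "the series" means these few. Any claim that something is new, unique, unknown or untested is made for them only; others in the source may bear on it.

In an ADME assay on Huh-7 cells (Homo sapiens) for inhibition, with a stated time of 3 days (a higher number here means that more compound is tolerated, a lower number that less compound is tolerated), compound 1 `O=C(/C=C/c1c(F)cc(C(F)(F)F)cc1F)NO` gives 12000 nM and compound 2 `O=C(/C=C/c1ccc(C(F)(F)F)cn1)NO` gives 13000 nM, two numbers within the usual scatter of each other. Compound 3 `O=C(NO)c1cc2ccccc2s1` gives 28000 nM, the highest of the three, and its gap to each of the others lies beyond the scatter. Compound 4 `O=C(NO)c1cc2cc(Cl)ccc2s1` has not yet been measured. It differs from compound 3 by one change: chloro in place of hydrogen on an aromatic carbon. Among the compounds with values here, no two measured compounds differ in only one place, so the data offer no direct guide to this step. There is only a weak hint: compound 1 and compound 2 both carry a trifluoromethyl group and sit lower than compound 3, though they differ from it in much else. The expected step is a 1.8-fold lower number from compound 3 to compound 4 (0.24 log units; within the scatter), a small fall that may stay within the scatter. For compound 4 the estimated value is 16000 nM, with an expected range of 7000 nM to 32000 nM.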

Compound 4, half-maximal cytotoxic concentration: 27000 nM
Beside the measured number, compound 4's estimate is 1.7-fold (0.23 log units) below it; measured number inside the range.
By their numbers in this assay, from the lowest: compounds 1 and 2 (each within the scatter of the next); then compounds 4 and 3 (each within the scatter of the next).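

In this assay, within the data shown here, a 1.0-fold lower number from compound 3 to compound 4 (0.02 log units; within the scatter) is the first step in this set that changes a single place, and it lies within the usual scatter. Compound 3 and compound 4 therefore cannot be told apart by this read-out, so at this aromatic carbon, on the six-membered ring of the fused system, chloro and hydrogen give numbers that match as closely as repeat measurements would. Nothing measured here gives a reason for this result.

On these data alone, it remains open whether a larger or differently built group at the same carbon, such as an amine, a carboxylic acid or a methoxy group, would also stay within the scatter of compound 3. Also open, as far as these compounds go, is whether chloro would give the same result on another carbon of this ring.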